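Swapping the Methoxy for a Methylamino Group

The source may hold more compounds than are shown below. What is called first, only, known or untested is meant among the compounds shown, and "the series" means these compounds.

Among the measured compounds shown here, compound 3 `COc1cc(-c2noc([C@H](C)NC(=O)c3cc(C(F)(F)F)nn3C)n2)cc(C)n1` holds the only plain number in this set: in an assay on T-REx-293 cells for inhibition of potassium channel subfamily T member 1 (Homo sapiens), read by patch clamp (a lower number here means a stronger inhibitor, a higher number a weaker inhibitor), compound 3 gives 505 nM. Compound 1 `Cc1cccc(-c2noc([C@H](C)NC(=O)c3cc(C(F)(F)F)nn3C)n2)n1` reaches only a limit of the assay, > 30000 nM. Compound 2 `C[C@H](NC(=O)c1cc(C(F)(F)F)nn1C)c1nc(-c2ccccn2)no1` likewise sits at a limit, > 30000 nM. Because of the limit of > 30000 nM in this assay, at which 2 of the 3 values shown sit, the two steps toward compound 3 can be read only as bounds: an at least 59-fold lower number from compound 1 to compound 3 (1.77 log units; beyond the scatter) and an at least 59-fold lower number from compound 2 to compound 3 (1.77 log units; beyond the scatter).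

Compound 4 `CNc1cc(-c2noc([C@H](C)NC(=O)c3cc(C(F)(F)F)nn3C)n2)ccn1` carries the change (2-(methylamino)pyridin-4-yl in place of 2-methoxy-6-methylpyridin-4-yl on an aromatic carbon). For the measured compounds named here, none of the measured steps bears directly on this exchange; the large steps ending at compound 3 swap one pyridinyl group for a differently substituted one, whereas compound 4 keeps the 2-methoxy-6-methylpyridin-4-yl attachment pattern and alters only its substituents. A step in this assay no larger than a modest one is therefore expected, with a slight lean toward a higher number. Compound 4 is estimated at 1200 nM, with a range from 300 nM to 5000 nM. As a step this estimate means a 2.4-fold higher number from compound 3 to compound 4 (0.38 log units; beyond the scatter).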

Compound 4, half-maximal inhibitory concentration: 195 nM
The estimate for compound 4 lay 6.2-fold (0.79 log units) above the measured number; measured number outside the range, below it.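

In this assay, the exchange gives a 2.6-fold lower number from compound 3 to compound 4 (0.41 log units; beyond the scatter), which shows that this place on the five-membered ring tolerates a substituted pyridine other than the 2-methoxy-6-methylpyridin-4-yl group and that the new group gives the lower number. Set against the two pyridin-2-yl groups, the 2-(methylamino)pyridin-4-yl group gives an at least 150-fold lower number from compound 2 to compound 4 (2.18 log units; beyond the scatter) and an at least 150-fold lower number from compound 1 to compound 4 (2.18 log units; beyond the scatter), so across the four compounds shown, both pyridin-4-yl groups carry plain numbers and both pyridin-2-yl groups sit at a limit, with none going against this. These two larger steps can be read only as bounds: the limit of > 30000 nM in this assay, at which 2 of the 4 values shown sit.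

The exchange both removes the ring methyl and replaces methoxy with methylamino, so the compounds shown leave open which of the two carries the step. As far as these compounds go, how a plain amino group or a dimethylamino group would read at this place also remains open.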